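Methoxy for Methyl on a Benzofuran Nucleoside

A few compounds are considered here, and "the series" means these few. Any claim that something is new, unique, unknown or untested is made for them only; others in the source may bear on it.

Compound 1 `Cc1ncnc2c1c(I)cn2[C@@H]1O[C@H](CO)[C@@H](O)[C@H]1O` gives 12600 nM in a functional assay on CEM-DNR-bulk cells (Homo sapiens), read by MTT assay, with a stated time of 72 h; on this read-out lower numbers stand for stronger inhibition and higher numbers for weaker inhibition. Compound 2 `Cc1ncnc2c1c(-c1cc3ccccc3o1)cn2[C@@H]1O[C@H](CO)[C@@H](O)[C@H]1O` reaches only the assay's limit > 20000 nM in this assay.

For the measured compounds named here, the one measured step, an at least 1.5-fold higher number from compound 1 to compound 2 (0.20 log units; that floor lies within the scatter), ends at a limit rather than a number, so compound 2 stands at the limit of > 20000 nM in this assay, at which 1 of the 2 values shown sits. Compound 3 `COc1ncnc2c1c(-c1cc3ccccc3o1)cn2[C@@H]1O[C@H](CO)[C@@H](O)[C@H]1O` differs from it by methoxy in place of methyl on an aromatic carbon. Going by the values given here, no measured step touches a methyl-to-methoxy exchange, so nothing here points to a shift in this assay beyond the scatter. Compound 3 is expected to move by a step that the limit leaves unreadable from compound 2 to compound 3. Compound 3 is estimated at 25000 nM, ranging from 12000 nM to 60000 nM, most likely again reported only as a limit.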

Compound 3, half-maximal inhibitory concentration: 10800 nM
Compound 3: middle estimate off by 2.3-fold (0.36 log units), on the high side; the whole stated range lies above it.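

The exchange of methyl for methoxy gives the only readable value among the 1-benzofuran-2-yl compounds shown: in this assay compound 3 gives 10800 nM. Compound 2 stands at a limit of the assay, > 20000 nM. The change is an at least 1.8-fold lower number from compound 2 to compound 3 (0.26 log units; that floor lies within the scatter); it starts from a limit, and its full size cannot be read.

On these data alone, whether ethoxy or an amine on this aromatic carbon would give a different number remains open. So does whether methoxy would have any such effect with iodo in place of 1-benzofuran-2-yl.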